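The source may report more compounds than this note shows. Statements on the series, on what has been measured and on what is new or still open speak of the compounds shown alone.

Measured compounds:
compound 1 `O=c1ccn(COCCO)c(=O)[nH]1` — in a functional assay on L1210 cells (Mus musculus) for inhibition (a higher number here means a weaker inhibitor, a lower number a stronger inhibitor), compound 1 gives a limit of > 1000 ug/mL
compound 2 `Cc1cn(COCCO)c(=O)[nH]c1=O` — in this assay compound 2 gives a limit of > 1000 ug/mL

Compound 2 stands at the ceiling of the numbers shown: its value is a limit, not a measured number. The same holds for compound 1, and the limit of > 1000 ug/mL in this assay, at which 2 of the 2 values shown sit, records that both values sit there. The step that the two limits leave unreadable from compound 1 to compound 2 therefore cannot be read in either size or direction.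

The account now turns to compound 3 `O=c1[nH]c(=O)n(COCCO)cc1[N+](=O)[O-]`, which is not yet measured. It differs from compound 2 as follows: nitro in place of methyl on an aromatic carbon.

For the measured compounds named here, only one measured step exists, and it is unreadable. No step in the shared core of these compounds has yet moved a value away from the limit, so the evidence offers no size or direction for the change from compound 2 to compound 3. Compound 3 is therefore expected to return a value near the same limit, with a step that the limit leaves unreadable from compound 2 to compound 3 as the estimated step. For compound 3 the estimate is 1500 ug/mL, with a range from 300 ug/mL to 6000 ug/mL.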

Compound 3, concentration for 50% inhibition: 447 ug/mL
Estimate against measurement, compound 3: 3.4-fold (0.53 log units) above, and the stated range covers the measured number.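

In this assay, for the compounds shown here, this position, on an aromatic carbon two atoms from the ring nitrogen, is the first place on the shared core where a change gives a readable direction: nitro in place of methyl gives an at least 2.2-fold lower number from compound 2 to compound 3 (0.34 log units; beyond the scatter), and nitro in place of hydrogen gives an at least 2.2-fold lower number from compound 1 to compound 3 (0.34 log units; beyond the scatter). Both steps point towards stronger inhibition, so the position is not silent in this assay, even though the step between the hydrogen and methyl compounds still cannot be read. The true size of each step remains open-ended, and only its minimum is known, because each starts from a compound held at a limit: the limit of > 1000 ug/mL in this assay, at which 2 of the 3 values shown sit.

The compounds shown leave open whether the gain belongs to nitro itself or would also appear with another group at this position, such as an amine, bromine or a carboxylic acid. They also leave open whether a longer chain in place of the group of 5 heavy atoms would shift the value of compound 3 further in either direction.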